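The compounds below may be only part of what the source reports. "The series", "measured", "known", "first", "only" and "open" are said of these compounds alone.

Measured so far:
compound 1, `COc1cncc(N2CCCNCC2)c1`: 1410 nM
compound 2, `c1cncc(N2CCCNCCC2)c1`: 36.3 nM
compound 3, `COc1cc(N2CCCNCC2)cnc1Cl`: 91.2 nM

All three were tested in a functional assay on HEK293 cells for agonist activity at Neuronal acetylcholine receptor; alpha4/beta2 (Homo sapiens), read by FLIPR and calcium flux; a lower number here means that less compound is needed, a higher number that more compound is needed for the effect. Compound 1 gives the highest number of the three, so of these it needs the most compound for the effect. Its nearest neighbour is compound 3, and the step of a 15-fold lower number from compound 1 to compound 3 (1.19 log units; beyond the scatter) is large and well beyond the scatter. Compound 2 lies furthest away; its value and that of compound 1 differ by even more, but compound 2 differs from compound 1 in more than one place, so no single change can be read from that pair.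

The new compound, compound 4, `NC(=O)c1cncc(N2CCCNCC2)c1`, differs from compound 1 in one place: carbamoyl in place of methoxy on an aromatic carbon.

Among the measured compounds shown here, no measured step here swaps one group for another on that aromatic carbon; the only single-place step is the addition of chloro elsewhere on the ring. The measured compounds therefore give little direct guidance on the carbamoyl. Since compound 1 is at the top of the range, and the other two show that changes to this core can bring the number down sharply, a lower number is expected for compound 4, but with wide uncertainty. The step of a 2.4-fold lower number from compound 1 to compound 4 (0.37 log units; beyond the scatter) is the expected change. Compound 4 is estimated at 600 nM, in the range 120 nM to 3000 nM.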

Compound 4, half-maximal effective concentration: 12900 nM
Compound 4: middle estimate off by 22-fold (1.33 log units), on the low side; measured number above the stated range.
By their numbers in this assay, from the lowest: compound 2; then compound 3; then compound 1; then compound 4.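

In this assay, the aromatic carbon two atoms from the ring nitrogen proves sensitive to the group it carries: carbamoyl in place of methoxy gives a 9.1-fold higher number from compound 1 to compound 4 (0.96 log units; beyond the scatter). This is the first single change shown at that carbon, and it runs in the opposite direction to the only earlier single change, chloro in place of hydrogen on another aromatic carbon, which gave a 15-fold lower number from compound 1 to compound 3 (1.19 log units; beyond the scatter), so changes to the core of compound 1 do not all lower the number. The swap also brings in a hydrogen-bond donor that methoxy does not have, but nothing measured here links that difference to the result, and no available evidence explains the rise.

As far as these compounds go, whether the rise is specific to carbamoyl or would follow from losing methoxy remains open; an amine, a nitrile, a carboxylic acid or a longer ether chain on the same carbon would help separate those two readings. It is also open whether chloro would lower the number on compound 4 as it does on compound 1, since only one carbamoyl compound is shown here.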